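Adding a chloro group to compound 2

The compounds below may be only part of what the source reports. "The series", "measured", "known", "first", "only" and "open" are said of these compounds alone.

compound 1 `CN(C)CCn1c(N)c(-c2nc3ccccc3[nH]2)c2nc(C#N)c(C#N)nc21`: 43500 nM
compound 2 `CN(C)CCCn1c(N)c(-c2nc3ccccc3[nH]2)c2nc(C#N)c(C#N)nc21`: 1820 nM
compound 3 `CN1CCN(CCCn2c(N)c(-c3nc4ccccc4[nH]3)c3nc(C#N)c(C#N)nc32)CC1`: 4520 nM

In a functional assay on cells (Homo sapiens) for antiproliferative activity, read by MTT assay, with a stated time of 48 h (a lower number here means a stronger inhibitor, a higher number a weaker inhibitor), compound 2 gives 1820 nM, the lowest number of the three. The gaps around it are a 2.5-fold higher number from compound 2 to compound 3 (0.40 log units; beyond the scatter) and a 24-fold lower number from compound 1 to compound 2 (1.38 log units; beyond the scatter), both beyond the usual scatter.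

Compound 4 `CN(C)CCCn1c(N)c(-c2nc3cc(Cl)ccc3[nH]2)c2nc(C#N)c(C#N)nc21` has not yet been measured. It differs from compound 2 in one place: chloro in place of hydrogen on an aromatic carbon. This is chloro in place of hydrogen on an aromatic carbon, turning 1H-benzimidazol-2-yl into 5-chloro-1H-benzimidazol-2-yl.

Going by the values given here, none of the measured steps touches that place. All of them, including a 24-fold lower number from compound 1 to compound 2 (1.38 log units; beyond the scatter) and a 9.6-fold lower number from compound 1 to compound 3 (0.98 log units; beyond the scatter), alter the saturated chain instead. They show that the number can move by a large amount, but they give no direct size for this change. With no direct guide, only a small lowering is expected, and it may stay within the scatter.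

The expected step is a 1.2-fold lower number from compound 2 to compound 4 (0.08 log units; within the scatter).

Compound 4 is estimated at about 1500 nM, with an expected range from 500 nM to 4500 nM.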

Compound 4, half-maximal inhibitory concentration: 28100 nM
Compound 4: middle estimate off by 19-fold (1.27 log units), on the low side, outside the stated range (above it).
By their numbers in this assay, from the lowest: compound 2; then compound 3; then compounds 4 and 1 (each within the scatter of the next).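

Replacing hydrogen with chloro, which turns 1H-benzimidazol-2-yl into 5-chloro-1H-benzimidazol-2-yl, gives a 15-fold higher number from compound 2 to compound 4 (1.19 log units; beyond the scatter) in this assay, so compound 4 is a much weaker inhibitor than compound 2. Going by these compounds alone, all the earlier steps altered the saturated chain, so this is the first sign that the number also responds to a change on the aromatic ring, and that a single added chlorine atom is enough to move it by a large amount. Nothing measured here accounts for this loss.

As far as these compounds go, what fluoro, methyl or methoxy would do on this same aromatic carbon stays open, so the loss cannot yet be tied to chloro in particular. From the compounds shown here alone, it is also open whether chloro here would weaken a compound carrying the 4-methylpiperazin-1-yl chain of compound 3 to a similar extent.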